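The source may hold more compounds than are shown below. What is called first, only, known or untested is meant among the compounds shown, and "the series" means these compounds.

Working notes on the series. Compound 1, `CC(C)(C)NC(=O)CCc1cccc2c1B(O)OC2`, is an amide bearing a tert-butyl group on the nitrogen; in a functional assay on MDA-MB-231 cells (Homo sapiens) for antiproliferative activity, read by MTT assay, with a stated time of 72 h (on this read-out lower numbers stand for stronger inhibition and higher numbers for weaker inhibition), compound 1 gives only a limit, > 100000 nM. Compound 2, `O=C(CCc1cccc2c1B(O)OC2)Nc1ccc(Cl)cc1`, carries a 4-chlorophenyl group on the same nitrogen, and in this assay compound 2 gives 3600 nM. The step of an at least 27-fold lower number from compound 1 to compound 2 (1.44 log units; beyond the scatter) is large, though the limit of > 100000 nM in this assay, at which 1 of the 2 values shown sits, means only its lower bound is known. For the measured compounds named here, compound 2 thus holds the only number so far; the other value in this assay is a limit.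

Compound 3, `CC(C)(C)OC(=O)Nc1ccc(NC(=O)CCc2cccc3c2B(O)OC3)cc1`, differs from compound 2 at the aromatic ring: (tert-butoxycarbonyl)amino in place of chloro on an aromatic carbon. Going by the values given here, the single measured step swapped the group on the amide nitrogen, so no measured step touches this change to the aromatic ring, and the (tert-butoxycarbonyl)amino group enters with no precedent. In this assay compound 3 is therefore expected to land near compound 2, with a 1.3-fold higher number from compound 2 to compound 3 (0.10 log units; within the scatter) estimated as no step beyond the scatter. The estimate for compound 3 in this assay is 4500 nM, with a range from 1200 nM to 20000 nM.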

Compound 3, half-maximal inhibitory concentration: 29000 nM
Compound 3: middle estimate off by 6.4-fold (0.81 log units), on the low side, outside the stated range (above it).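

For the compounds shown here, this is the first measured change on the aromatic ring, and the position is not indifferent to its substituent: in this assay, an 8.1-fold higher number from compound 2 to compound 3 (0.91 log units; beyond the scatter), with (tert-butoxycarbonyl)amino in place of chloro. The step goes in the direction of weaker inhibition, so of the two groups shown at this place, chloro goes with the stronger inhibition, but the change swaps a single chlorine atom for a much larger group that also brings a hydrogen-bond donor and hydrogen-bond acceptors, and one step cannot separate group size from these added features. Compound 1 remains a limit rather than a number: the limit of > 100000 nM in this assay, at which 1 of the 3 values shown sits.

Going by these compounds, with only chloro and (tert-butoxycarbonyl)amino at this place, it remains open whether a small amine or a carboxylic acid on the same aromatic carbon would read closer to compound 2 or to compound 3. Also open, on these data alone, is whether a longer chain linking the amide to the shared core would shift the numbers in this assay in the same way for both aromatic groups.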